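The compounds below may be only part of what the source reports. "The series", "measured", "known", "first", "only" and "open" are said of these compounds alone.

Compound 1 `COc1ccc2[nH]cc(-c3nc(C(=O)Nc4cc(OC)c(OC)c(OC)c4)cs3)c2c1`: > 100000 nM
Compound 2 `COc1cc(NC(=O)c2csc(-c3c[nH]c4ccc(Br)cc34)n2)cc(OC)c1OC`: > 100000 nM
Compound 3 `O=C(Nc1ccccc1)c1csc(-c2cn(Cc3ccc(Cl)cc3)c3ccccc23)n1`: > 100000 nM

In a functional assay on MDA-MB-231 cells (Homo sapiens) for cytotoxicity, read by MTT assay, with a stated time of 48 h, in the presence of a further agent that is not named here (a lower number here means a stronger inhibitor, a higher number a weaker inhibitor), compound 1 gives > 100000 nM, which is a limit of the assay and not a number. Compound 2 gives > 100000 nM, also a limit. Compound 3 gives > 100000 nM, again a limit. The step that the two limits leave unreadable from compound 1 to compound 2 cannot be read, since both ends are limits. For the measured compounds named here, all three values sit at the limit of > 100000 nM in this assay, at which 3 of the 3 values shown sit, so no measured step shows a readable size.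

Compound 4 `COc1cc(NC(=O)c2csc(-c3cn(Cc4ccc(Cl)cc4)c4ccccc34)n2)cc(OC)c1OC` differs from compound 3 by 3,4,5-trimethoxyphenyl in place of phenyl on an amide-type nitrogen. Going by the values given here, the group that enters is the one that compounds 1 and 2 already carry on the amide nitrogen, and both of those compounds sit at the limit, as does compound 3. Among the compounds with values here, no measured step bears directly on this change, and nothing in the values suggests a move off the limit. The expected step, a number no higher from compound 3 to compound 4 (the limit leaves the size open), is therefore none beyond the scatter. Compound 4 is expected to give about 100000 nM, within a range from 30000 nM to 300000 nM, most likely reported as a limit.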

Compound 4, half-maximal inhibitory concentration: > 100000 nM
Compound 4 was reported as a limit; the forecaster's own chance of this, stated with the estimate: 85%; the middle value lies on the limit itself.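

Compound 3 and compound 4 both stand at a limit of the assay, not at a number, so the step between them, 3,4,5-trimethoxyphenyl in place of phenyl, cannot be read. The compounds shown leave open which change, if any, would bring a value off this limit: the limit of > 100000 nM in this assay, at which 4 of the 4 values shown sit.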